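Phenyl in place of 2-(pyridin-2-yl)ethyl on the oxygen

The source may report more compounds than this note shows. Statements on the series, on what has been measured and on what is new or still open speak of the compounds shown alone.

Compound 1 `O=C(Nc1cccc(OCCc2ccccn2)c1)C1CCCN(C(=O)c2cc(C(F)(F)F)cc(C(F)(F)F)c2)C1` was run in a functional assay on PC-3 cells (Homo sapiens), with a stated time of 24 h, tested at 10 uM; on this read-out higher numbers stand for more inhibition at the one concentration tested (going by the name of the read-out) and lower numbers for less inhibition. In this assay compound 1 gives < 30%, which is a limit of the assay and not a number, so where compound 1 stands is known only as a range (the limit of < 30% in this assay, at which 1 of the 2 values shown sits). Compound 2 `O=C(Nc1ccc(Cl)cc1)C1CCCN(C(=O)c2cccc(-c3cccs3)c2)C1` shares the core but differs from compound 1 at several places; in this assay compound 2 gives 70%. Within the data shown here, no pair of measured compounds differing in one place is available, so no measured step sets the size of the change. Compound 3 `O=C(Nc1cccc(Oc2ccccc2)c1)C1CCCN(C(=O)c2cc(C(F)(F)F)cc(C(F)(F)F)c2)C1` carries phenyl in place of 2-(pyridin-2-yl)ethyl on an oxygen on an aromatic ring. Since compound 1 sits at a limit, a modest upward step is expected, a number no lower from compound 1 to compound 3 (the limit leaves the size open), probably not beyond the scatter. Compound 3 is estimated at 30%, with a range from 5% to 60%.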

Compound 3, a percentage reported as inhibition, at one concentration (the size of the read-out at that concentration, not a potency): < 30%
Compound 3 was reported as a limit; the forecaster's own chance of this, stated with the estimate: 50%; the middle value lies on the limit itself.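

Compound 1 and compound 3 are both reported as limits in this assay, so no step can be read for phenyl in place of 2-(pyridin-2-yl)ethyl: the limit of < 30% in this assay, at which 2 of the 3 values shown sit.

From the compounds shown here alone, whether these two groups on the oxygen differ at all in this assay remains open.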